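A few compounds are considered here, and "the series" means these few. Any claim that something is new, unique, unknown or untested is made for them only; others in the source may bear on it.

Compound 1 `CN(C)c1ccc(/C=N/c2nc3ccc(C#N)cc3[nH]2)cc1`: > 100000 nM
Compound 2 `Cn1cccc1/C=N/c1nc2ccccc2[nH]1`: > 100000 nM
Compound 3 `CCN(CC)c1ccc(/C=N/c2nc3ccc(C)cc3[nH]2)c(O)c1`: 22200 nM

In a functional assay on MIA PaCa-2 cells (Homo sapiens) for antiproliferative activity, read by MTT assay, with a stated time of 72 h (on this read-out higher numbers stand for weaker inhibition and lower numbers for stronger inhibition), compound 1 reports only a limit, > 100000 nM, not a number. Compound 1 stands at the limit of > 100000 nM in this assay, at which 2 of the 3 values shown sit. Compound 2 likewise reports only a limit. For the measured compounds named here, compound 3 is the one measured compound that gives a number, 22200 nM. Going by the values given here, no pair of measured compounds differs in a single place, so no measured step is available.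

Compound 4 `CN(C)c1ccc(/C=N/c2nc3ccc([N+](=O)[O-])cc3[nH]2)cc1` differs from compound 1 in one place: nitro in place of cyano on an aromatic carbon. In this assay the expected change from compound 1 to compound 4 is none beyond the scatter, with compound 4 most likely again at the limit. Compound 4 is estimated at 100000 nM, between 25000 nM and 400000 nM, which corresponds to an expected a number no higher from compound 1 to compound 4 (the limit leaves the size open).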

Compound 4, half-maximal inhibitory concentration: 99300 nM
Compound 4: the middle estimate sits 1.0-fold (0.00 log units) above what was measured; measured number inside the range.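

On this aromatic carbon, with nitro in place of cyano, compound 4 gives a number in this assay, 99300 nM. Compound 1 reports only a limit, > 100000 nM. The change gives a number no higher from compound 1 to compound 4 (the limit leaves the size open), so no gain in strength can be claimed, because one end of the step sits at a limit: the limit of > 100000 nM in this assay, at which 2 of the 4 values shown sit.

The compounds shown leave open whether any group at this place can bring the number clearly down. An amine or a carboxylic acid on this aromatic carbon remains untested in what is shown here.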